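Swapping the Isobutoxy Chain for a Methylsulfonylpropoxy Chain

This account rests on a few compounds, and the source may have more. Where it says the series, first, only, none or still open, it means among the compounds named here.

In a functional assay on CHO cells for agonist activity at Free fatty acid receptor 1 (Homo sapiens), read by FLIPR and calcium flux (on this read-out lower numbers stand for an effect already at smaller amounts and higher numbers for an effect only at larger amounts of compound), compound 3 `Cc1cc(OCC(C)C)cc(C)c1-c1cccc(COc2ccc(S(=O)(=O)CC(=O)O)cc2)c1` gives 95.5 nM. For the measured compounds named here, compound 2 `Cc1cccc(C)c1-c1cccc(COc2ccc(S(=O)(=O)CC(=O)O)cc2)c1` gives 66.1 nM in this assay, and the step of a 1.4-fold higher number from compound 2 to compound 3 (0.16 log units; within the scatter) is the only measured change at this position. Compound 1 `Cc1cc(OCCCS(C)(=O)=O)cc(C)c1-c1cccc(COc2ccc(CCC(=O)O)cc2)c1` gives 15.5 nM in this assay, well apart from compound 3, but it also carries a different acid part, so its number alone shows only what that combination does. Compound 4 `Cc1cc(OCCCS(C)(=O)=O)cc(C)c1-c1cccc(COc2ccc(S(=O)(=O)CC(=O)O)cc2)c1` is not yet measured; it differs from compound 3 by 2-(methylsulfonyl)ethyl in place of isopropyl on a saturated chain carbon bound to an oxygen on an aromatic ring. Going by the values given here, the one relevant step, from hydrogen to isobutoxy, stayed within the scatter, so no firm expectation follows from it. The step of a 2.4-fold lower number from compound 3 to compound 4 (0.38 log units; beyond the scatter) is expected to be a modest move toward a lower number. Compound 4 is estimated at 40 nM, within 12 nM to 130 nM.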

Compound 4, half-maximal effective concentration: 170 nM
Estimate against measurement, compound 4: 4.3-fold (0.63 log units) below, outside the stated range (above it).
By their numbers in this assay, from the lowest: compound 1; then compounds 2, 3 and 4 (each within the scatter of the next, the first and the last beyond it).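

In this assay, exchanging the isobutoxy chain for the 3-(methylsulfonyl)propoxy chain gives a 1.8-fold higher number from compound 3 to compound 4 (0.25 log units; within the scatter) and so does not separate the two chains, yet a 2.6-fold higher number from compound 2 to compound 4 (0.41 log units; beyond the scatter) puts the new chain, unlike isobutoxy, beyond the scatter from hydrogen at this place. With that chain held fixed, an 11-fold higher number from compound 1 to compound 4 (1.04 log units; beyond the scatter) shows that the acid part has the larger effect here. No measurement here explains these differences. Still open, from the compounds shown here alone, is how an amine or a carboxylic acid at the end of this chain would read.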